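The compounds below may be only part of what the source reports. "The series", "measured", "known", "first", "only" and "open" are said of these compounds alone.

Working notes on the series.

Two measured compounds frame the question. Compound 1 `COc1ccc(C(=O)/C(=C\c2ccc(O)c([N+](=O)[O-])c2)SCc2ccc(Br)cc2)cc1` was tested in a functional assay on DU-145 cells (Homo sapiens) for inhibition, read by trypan blue exclusion, with a stated time of 96 h (on this read-out higher numbers stand for weaker inhibition of growth and lower numbers for stronger inhibition of growth), where compound 1 gives 10000 nM. Compound 2 `O=C(/C(=C/c1ccc(Cl)cc1)Cc1c[nH]c2ccccc12)c1ccc(Cl)cc1Cl` shares the enone arrangement but differs at several points, and in this assay compound 2 gives 10000 nM. The two values sit level at the digits shown, within the scatter, so nothing separates compound 1 from compound 2 here; no single-point step between them exists.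

The next compound, compound 3 `O=C(/C(=C\c1ccc(O)c([N+](=O)[O-])c1)SCc1ccc(Br)cc1)c1ccc([N+](=O)[O-])cc1`, departs from compound 1 at one place only: nitro in place of methoxy on an aromatic carbon. Nothing in the measured pair speaks to this exchange, and both measured values lie at the same point, so the step from compound 1 to compound 3 is expected to be none beyond the scatter, as no change at the digits printed from compound 1 to compound 3 (within the scatter). Compound 3 is therefore estimated at 10000 nM, with a range from 3000 nM to 25000 nM.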

Compound 3, concentration for 50% growth inhibition: 10000 nM
For compound 3 middle estimate and measured number coincide at the digits printed; the range from low to high includes it.
By their numbers in this assay, from the lowest: compounds 1, 2 and 3 (each within the scatter of the next).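

In this assay, nitro in place of methoxy on an aromatic carbon, para to a large group, gives no change at the digits printed from compound 1 to compound 3 (within the scatter). This is the only single-place step shown so far, and it indicates that the exchange of 4-methoxyphenyl for 4-nitrophenyl on the core of compound 1 does not separate the two compounds, with compound 3 giving 10000 nM in this read-out. No measurement on hand offers an explanation for this outcome.

All three values are level, so the compounds shown do not tell whether an amine or a carboxylic acid at this position would shift the number in this assay. They also leave open whether the same exchange of methoxy for nitro would read alike on a core with stronger inhibition of growth.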